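A few compounds are considered here, and "the series" means these few. Any claim that something is new, unique, unknown or untested is made for them only; others in the source may bear on it.

Measured compounds in a functional assay on L1210 cells (Mus musculus) for inhibition; a lower number here means a stronger inhibitor, a higher number a weaker inhibitor:

Compound 1, `CCOC(=O)Nc1cc(N/N=C/c2ccccc2)c(N)c(N)n1`: 4600 nM
Compound 2, `CCOC(=O)Nc1cc2c(ncn2/N=C/c2ccccc2)c(N)n1`: 150 nM
Compound 3, `CCOC(=O)Nc1cc(N/N=C/c2ccccc2)c2[nH]c(S)nc2n1`: 1500 nM

Among these three, compound 2 gives the lowest number in this assay, and its gaps to compound 3 and to compound 1 are both beyond the scatter of repeated measurements, so compound 2 is the strongest inhibitor of the set. The step followed here goes from compound 2 to compound 4, `CCOC(=O)Nc1cc2c(nc(SCc3ccccc3)n2/N=C/c2ccccc2)c(N)n1`, which has not yet been measured in this assay. The structural change is benzylsulfanyl in place of hydrogen on an aromatic carbon. Nothing in the measured set shows what such a change does on this core, so the expectation rests on compound 2 alone. A modest weakening is expected, with the step from compound 2 to compound 4 estimated at a 2.7-fold higher number from compound 2 to compound 4 (0.43 log units; beyond the scatter), a step that only just reaches beyond the scatter. Compound 4 is therefore expected to give about 400 nM in this assay, with a plausible range from 100 nM to 2000 nM.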

Compound 4, half-maximal inhibitory concentration: 50000 nM
Compound 4: the middle estimate sits 130-fold (2.10 log units) below what was measured, outside the stated range (above it).
By their numbers in this assay, from the lowest: compound 2; then compound 3; then compound 1; then compound 4.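

On the shared core of compound 2, the aromatic carbon between two ring nitrogen atoms proves highly sensitive to substitution: in this assay, placing benzylsulfanyl there in place of hydrogen gives a 330-fold higher number from compound 2 to compound 4 (2.52 log units; beyond the scatter) and so costs most of the inhibition. Going by these compounds alone, the earlier compounds offered no step at this carbon, so this single pair is the first sign that the position is far from indifferent to what it carries.

On these data alone, what remains open is whether any group on this carbon brings such a loss or whether it belongs to benzylsulfanyl in particular: methyl, an amine or methylsulfanyl in the same place would separate these possibilities. Nothing in the available data says why inhibition falls so far.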